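Dropping One Methoxy Group from a Chalcone-Type Scaffold

This account rests on a few compounds, and the source may have more. Where it says the series, first, only, none or still open, it means among the compounds named here.

Of the compounds shown here, two of a shared core have been tested in a functional assay on DU-145 cells (Homo sapiens) for antiproliferative activity, read by MTT assay, with a stated time of 24 h; a lower number here means a stronger inhibitor, a higher number a weaker inhibitor. Compound 1 `COc1cc(-c2cc(/C=C/C(=O)c3ccccc3)nc3cc(-c4ccccc4)nn23)cc(OC)c1OC` gives 34300 nM, while compound 2 `COc1ccc(C(=O)/C=C/c2cc(-c3ccc(OC)cc3)n3nc(-c4ccccc4)cc3n2)cc1` gives 8500 nM. Compound 2 has the lower number of the two, and the gap to compound 1 lies beyond the usual scatter of this kind of measurement, so compound 2 is the stronger inhibitor of the pair.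

The next compound, compound 3 `COc1ccc(-c2cc(/C=C/C(=O)c3ccccc3)nc3cc(-c4ccccc4)nn23)cc1`, departs from compound 2 in a single place: hydrogen in place of methoxy on an aromatic carbon. Put simply, a methoxy group on the benzoyl ring is replaced by a hydrogen atom, so that the (4-methoxyphenyl)carbonyl end of the molecule becomes a plain benzoyl. The rest of the structure, including the second methoxyphenyl on the core, is unchanged.

Within the data shown here, no measured pair in this set isolates this exact change, so there is no direct precedent to lean on. In this assay the expected step is a 1.4-fold higher number from compound 2 to compound 3 (0.15 log units; within the scatter), a small change that would plausibly be a mild loss of potency without clearly exceeding the scatter. Compound 3 is therefore estimated at 12000 nM, with a likely range from 4000 nM to 36000 nM.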

Compound 3, half-maximal inhibitory concentration: 13700 nM
The estimate for compound 3 lay 1.1-fold (0.06 log units) below the measured number, and the stated range covers the measured number.
By their numbers in this assay, from the lowest: compounds 2 and 3 (each within the scatter of the next); then compound 1.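

In this assay, replacing the methoxy group on the benzoyl ring with hydrogen gives a 1.6-fold higher number from compound 2 to compound 3 (0.21 log units; within the scatter), so this swap, at a position para to a large group, has no effect that can be told apart from ordinary repeat-to-repeat variation. Compound 3 also gives compound 1 its first partner that differs in only one place: a 2.5-fold lower number from compound 1 to compound 3 (0.40 log units; beyond the scatter) with 4-methoxyphenyl in place of 3,4,5-trimethoxyphenyl, a modest gain in potency that, unlike the benzoyl change, lies beyond the scatter. The data offer no explanation for either step.

Hydrogen and methoxy are the only groups shown at the benzoyl position, so it remains open whether an amine or a carboxylic acid there would leave the number in the same range or move it clearly. Going by these compounds, it is also open how far the trend on the other ring extends, for instance whether a plain phenyl in place of the 4-methoxyphenyl on the core would continue it or reverse it.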